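The source may report more compounds than this note shows. Statements on the series, on what has been measured and on what is new or still open speak of the compounds shown alone.

Measured compounds:
compound 1, `O=c1cc(CSc2nc3ccccc3s2)oc2ccccc12`: > 25000 nM
compound 2, `Cc1ccc2oc(CSc3nc4nc(C)cc(C)n4n3)cc(=O)c2c1`: > 25000 nM

Both compounds were tested in a functional assay on MDA-MB-435S cells (Homo sapiens) for cytotoxicity, read by MTT assay, with a stated time of 72 h; a lower number here means a stronger inhibitor, a higher number a weaker inhibitor. For compound 1 the assay reports no number but only a limit, > 25000 nM. For compound 2 the result is likewise only a limit, > 25000 nM. Within the data shown here, compound 1 therefore stands nowhere in particular on a scale of numbers: all that is known is that it sits at the limit, together with the only other measured compound, as summed up in the limit of > 25000 nM in this assay, at which 2 of the 2 values shown sit.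

The unmeasured compound 3, `Cc1ccc2oc(CSc3nc4ccccc4s3)cc(=O)c2c1`, is built from compound 1 by a single change: methyl in place of hydrogen on an aromatic carbon. Among the measured compounds shown here, no step between two measured compounds is available to say what such a change does here, so the expectation for compound 3 can rest only on where compound 1 sits. Since both measured values sit at the limit of > 25000 nM in this assay, at which 2 of the 2 values shown sit, the expected step that the limit leaves unreadable from compound 1 to compound 3 is none beyond the usual scatter, with the result most likely again reported as a limit. Compound 3 is thus estimated at 40000 nM, within a range of 15000 nM to 120000 nM.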

Compound 3, half-maximal inhibitory concentration: > 25000 nM
Compound 3 was reported as a limit; the forecaster's own chance of this, stated with the estimate: 80%; the middle value does not contradict the limit.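

Compound 1 and compound 3 are both reported only as limits, not as numbers, so no step can be read between them for methyl in place of hydrogen on an aromatic carbon. The compounds shown leave open which change to the shared core, if any, would give an actual number, as all of them sit at one mark: the limit of > 25000 nM in this assay, at which 3 of the 3 values shown sit.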